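A few compounds are considered here, and "the series" means these few. Any claim that something is new, unique, unknown or untested is made for them only; others in the source may bear on it.

Working notes on a small set tested in an assay on isolated protein for inhibition of MAP kinase-activated protein kinase 2 (Homo sapiens), read by HTRF, tested at 10 uM; a higher number here means more inhibition at the concentration tested (going by the name of the read-out), a lower number less inhibition. Compound 1 (`Cc1cccc(Oc2ccnc(N3CCC[C@H]3C(=O)NCCCn3ccnc3)n2)c1`) gives 2% in this assay. Compound 2 (`Clc1ccc2sc(CN3CCN(c4ncnc5c4CN(Cc4ccccc4)CC5)CC3)cc2c1`) gives 1%, and compound 3 (`Cc1cccc(N(C)c2cc(Nc3cccc(C(=O)N4CCCC5CCCCC54)c3)ncn2)c1`) gives 0%. Compound 1 stands within the usual scatter of both compound 2 and compound 3, so the three readings are treated as one level: close to no inhibition at the concentration tested. Going by the values given here, no two of the measured compounds differ in only one place, so no single structural step has a measured size in this set.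

Compound 4 (`COC(=O)C(CO)NC(=O)[C@@H]1CCCN1c1nccc(Oc2cccc(C)c2)n1`) has not yet been measured. It differs from compound 1 as follows: 2-hydroxy-1-(methoxycarbonyl)ethyl in place of 3-(1H-imidazol-1-yl)propyl on an amide-type nitrogen. The exchange sits on an amide-type nitrogen whose other neighbour is the carbonyl carbon; the same difference, cut one bond further out, reads (3-(1H-imidazol-1-yl)propyl)amino to (2-hydroxy-1-(methoxycarbonyl)ethyl)amino. Nothing measured here connects such an exchange to a change in this assay, and the whole set sits near the bottom of the read-out. The expected step is therefore no change at the digits printed from compound 1 to compound 4 (within the scatter), none beyond the scatter. Compound 4 is estimated at 2% in this assay, with a range from -6% to 10%.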

Compound 4, a percentage reported as inhibition, at one concentration (the size of the read-out at that concentration, not a potency): 1%
Estimate against measurement, compound 4: 1 percentage points above, and the stated range covers the measured number.
By their numbers in this assay, from the lowest: compounds 3, 2, 4 and 1 (each within the scatter of the next).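

Going by these compounds alone, this is the first measured step in the set, and it sits on the amide-type nitrogen of the shared core: in this assay, 2-hydroxy-1-(methoxycarbonyl)ethyl in place of 3-(1H-imidazol-1-yl)propyl gives a number 1 percentage points lower from compound 1 to compound 4 (within the scatter). The exchange removes the five-membered aromatic ring and brings in a group with no ring and a hydroxyl, yet the reading stays at the same level, close to no inhibition, so this assay does not separate these two groups at this position. Nothing available on measured properties or binding bears on this result.

From the compounds shown here alone, what remains open is whether any group on this nitrogen can lift the reading clear of the scatter, for example a carboxylic acid in place of the methyl ester, or a primary amine on a longer chain in place of the imidazole. Going by these compounds, with both compounds this close to no inhibition, it also remains open whether the same exchange would have any measurable size on a compound that shows clear inhibition.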